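Replacing 4-fluorobenzyl with 2-isopropylphenyl on an inactive core

A few compounds are considered here, and "the series" means these few. Any claim that something is new, unique, unknown or untested is made for them only; others in the source may bear on it.

Compound 1, `Cc1ccc(Nc2ncc(Cl)c(Nc3ccccc3C)n2)cc1`: in a functional assay on Jurkat cells (Homo sapiens) for inhibition, read by CCK-8 assay, with a stated time of 48 h (a lower number here means a stronger inhibitor of growth, a higher number a weaker inhibitor of growth), compound 1 gives > 100000 nM, a limit of the assay.
Compound 2, `Cc1ccccc1Nc1nc(NCc2ccccc2)ncc1Cl`: in this assay compound 2 gives > 100000 nM, again a limit.
Compound 3, `CN1CCN(c2ccc(Nc3ncc(Cl)c(NCc4ccc(F)cc4)n3)nc2)CC1`: in this assay compound 3 gives > 100000 nM, also a limit.

Compound 3 therefore stands where every measured compound stands: at the limit of the assay, with no number beneath it. Among the measured compounds shown here, the evidence is the limit of > 100000 nM in this assay, at which 3 of the 3 values shown sit, so no compound here shows measurable growth inhibition.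

Compound 4, `CC(C)c1ccccc1Nc1nc(Nc2ccc(N3CCN(C)CC3)cn2)ncc1Cl`, has not yet been measured. The change from compound 3 is 2-isopropylphenyl in place of 4-fluorobenzyl on a nitrogen on an aromatic ring.

For the measured compounds named here, only one measured step relates to this kind of change. The step that the two limits leave unreadable from compound 1 to compound 2 also exchanges an aryl group for a benzyl group on a ring nitrogen, in the opposite direction, but both of its values are limits, so its size is unreadable. Nothing measured here shows that swapping a benzyl for an aryl on that nitrogen moves the read-out at all.

The expectation is accordingly that compound 4 again reaches only the limit, with a step of a number no higher from compound 3 to compound 4 (the limit leaves the size open) that is not readable. Compound 4 is estimated at 100000 nM, within 20000 nM to 300000 nM.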

Compound 4, concentration for 50% growth inhibition: 5140 nM
The estimate for compound 4 lay 19-fold (1.29 log units) above the measured number, and the stated range ends above it.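

Exchanging 4-fluorobenzyl for 2-isopropylphenyl on a nitrogen on an aromatic ring gives an at least 19-fold lower number from compound 3 to compound 4 (1.28 log units; beyond the scatter) in this assay. Among the compounds shown here, this is the first readable step in the set, and it shows that the group at this place can decide whether any growth inhibition is measured at all, since the rest of the structure is the same in both compounds. For the compounds shown here, the earlier benzyl-for-aryl step could not show this, as both of its ends are limits, and compound 4 is the only compound of the four to come off the limit: the limit of > 100000 nM in this assay, at which 3 of the 4 values shown sit.

The change bundles several differences into one step: the fluorine goes, an isopropyl group arrives, and the ring loses the carbon that linked it to the nitrogen, so the compounds shown cannot say which of these matters. They also leave open how this position would respond to other groups in place of the isopropyl, such as a methoxy group, an amine or a carboxylic acid, and whether the number could fall further.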